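A few compounds are considered here, and "the series" means these few. Any claim that something is new, unique, unknown or untested is made for them only; others in the source may bear on it.

In a functional assay on A549 cells (Homo sapiens) for antiproliferative activity, read by MTT assay, with a stated time of 24 h (a higher number here means a weaker inhibitor, a lower number a stronger inhibitor), compound 1 (`Cc1cccc(NNC(=O)c2ccccc2NS(=O)(=O)c2cnc(O)nc2O)c1`) reads > 20000 nM and this is a limit of the assay. Going by the values given here, compound 2 (`O=C(NNc1ccccc1Cl)c1ccccc1NS(=O)(=O)c1cnc(O)nc1O`) gives a true number of 5480 nM in this assay for the series so far. Compound 3 (`Cc1ccc(C(=O)NNC(=O)c2ccccc2NS(=O)(=O)c2cnc(O)nc2O)cc1`) reads > 20000 nM and this too is a limit, so it has no number and sits at the limit of > 20000 nM in this assay, at which 2 of the 3 values shown sit, with compound 1.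

Compound 4 (`O=C(NNC(=O)c1ccccc1NS(=O)(=O)c1cnc(O)nc1O)c1cccc(Cl)c1`) has 3-chlorophenyl in place of 4-methylphenyl on a carbonyl carbon. Among the compounds with values here, no measured step makes this exchange. The closest is an at least 3.6-fold lower number from compound 1 to compound 2 (0.56 log units; beyond the scatter) where a chlorophenyl group replaces a methylphenyl group, though on an amine nitrogen and with the chlorine placed differently. The return to the limit, an at least 3.6-fold higher number from compound 2 to compound 3 (0.56 log units; beyond the scatter), sets compound 3 clearly behind compound 2 but says nothing about chlorine on the carbonyl side. The remaining pair gives a step that the two limits leave unreadable from compound 1 to compound 3 and adds nothing. With one indirect step as support, only a modest move towards a lower number is expected in this assay and a reading that stays at the limit remains quite possible. The expected change is an at least 1.4-fold lower number from compound 3 to compound 4 (0.15 log units; that floor lies within the scatter) and it rests on that single step. For compound 4 the estimate is 14000 nM with an expected range from 5000 nM to 35000 nM in this assay.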

Compound 4, half-maximal inhibitory concentration: 1260 nM
Beside the measured number, compound 4's estimate is 11-fold (1.05 log units) above it; measured number below the stated range.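

On a carbonyl carbon whose other neighbours are an amide-type nitrogen, 3-chlorophenyl in place of 4-methylphenyl turns a reading at the limit into a true number in this assay, with an at least 15-fold lower number from compound 3 to compound 4 (1.20 log units; beyond the scatter). The carbonyl-linked aryl arm therefore does not hold the series at the limit in itself, and the (3-chlorophenyl)carbonyl group also goes past the 2-chlorophenyl group on an amine nitrogen, with a 4.3-fold lower number from compound 2 to compound 4 (0.64 log units; beyond the scatter), and past the 3-methylphenyl group there, with an at least 15-fold lower number from compound 1 to compound 4 (1.20 log units; beyond the scatter). Compound 1 and compound 3 remain limits and not numbers, so the steps from them give only a floor on the size of the change: the limit of > 20000 nM in this assay, at which 2 of the 4 values shown sit.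

Going by these compounds, whether the drop belongs to the chlorine or to its placement on the ring stays open, as this exchange alters both at once. Also open, on these data alone, is how this carbonyl carbon tolerates a group other than a substituted phenyl, such as a cyclohexyl ring, a longer alkyl chain or a phenyl ring carrying a carboxylic acid.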